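A few compounds are considered here, and "the series" means these few. Any claim that something is new, unique, unknown or untested is made for them only; others in the source may bear on it.

Measured compounds:
compound 1 `COc1cc2c(cc1OC)C(=O)C(CC1CCN(C(=S)Nc3cccc(Cl)c3)CC1)C2` — 300 mg/kg
compound 2 `COc1cc2c(cc1OC)C(=O)C(CC1CCN(C(=S)Nc3ccc(Cl)cc3)CC1)C2` — 30 mg/kg

In a functional assay on the whole organism (strain Swiss albino) with Mus musculus as the target, in the maximal electroshock model, with a stated time of 0.5 h (on this read-out lower numbers stand for an effect already at smaller amounts and higher numbers for an effect only at larger amounts of compound), compound 2 gives 30 mg/kg, the lowest of the two numbers. Compound 1 gives 300 mg/kg. Among the measured compounds shown here, the single measured step, a 10-fold lower number from compound 1 to compound 2 (1.00 log units; beyond the scatter), lies beyond the scatter. Compound 3 `CCCNC(=S)N1CCC(CC2Cc3cc(OC)c(OC)cc3C2=O)CC1` differs from compound 2 by propyl in place of 4-chlorophenyl on an amide-type nitrogen. No measured step covers an exchange of 4-chlorophenyl for propyl on this nitrogen, so the shown numbers give no direct guide to direction or size; a higher number than compound 2 is taken as the working expectation. Compound 3 is expected at 100 mg/kg, range 30 mg/kg to 300 mg/kg. This expected step is a 3.3-fold higher number from compound 2 to compound 3 (0.52 log units; beyond the scatter).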

Compound 3, minimum effective dose: 100 mg/kg
Estimate against measurement, compound 3: no gap at the digits printed; measured number inside the range.
By their numbers in this assay, from the lowest: compound 2; then compound 3; then compound 1.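

In this assay, a ring on this amide-type nitrogen is not needed for an effect: propyl falls between the two chlorophenyl compounds, giving a higher number than 4-chlorophenyl (a 3.3-fold higher number from compound 2 to compound 3 (0.52 log units; beyond the scatter)) and a lower one than 3-chlorophenyl (a 3.0-fold lower number from compound 1 to compound 3 (0.48 log units; beyond the scatter)). The exchange of 3-chlorophenyl for 4-chlorophenyl therefore remains the largest step among these three compounds. No evidence on the cause of this order is at hand. Still open, on these data alone, is whether a longer chain such as hexyl, or a benzyl group, on this nitrogen would match or go below the number of compound 2.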